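Swapping the Sulfonyl Group of Compound 3

A few compounds are considered here, and "the series" means these few. Any claim that something is new, unique, unknown or untested is made for them only; others in the source may bear on it.

Measured so far in a functional assay on DLD-1 cells (Homo sapiens) for antiproliferative activity, read by CellTiter-Glo, with a stated time of 72 h; a lower number here means a stronger inhibitor, a higher number a weaker inhibitor
Compound 1 `Cc1cccc(S(=O)(=O)N2CCC(N3CCC(C)CC3)CC2)c1` - 25 nM
Compound 2 `CC1CCN(C2CCN(S(=O)(=O)c3ccc(Br)c(Cl)c3)CC2)CC1` - 12 nM
Compound 3 `CC1CCN(C2CCN(S(=O)(=O)c3cn(C)cn3)CC2)CC1` - > 5000 nM (a limit, not a number)

Compound 3 stands at > 5000 nM as a limit of the assay and not as a number. Compound 4 `CC1CCN(C2CCN(S(=O)(=O)c3cc(Cl)cc(Cl)c3)CC2)CC1` has 3,5-dichlorophenyl in place of 1-methyl-1H-imidazol-4-yl on a sulfonyl sulfur.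

Within the data shown here, three measured steps bear on this change. Putting 1-methyl-1H-imidazol-4-yl in place of 3-methylphenyl gave an at least 200-fold higher number from compound 1 to compound 3 (2.30 log units; beyond the scatter) and is a large step. Putting it in place of 4-bromo-3-chlorophenyl gave an at least 410-fold higher number from compound 2 to compound 3 (2.61 log units; beyond the scatter) and is also large. The exchange between the two phenyl groups mattered far less, with a 2.1-fold lower number from compound 1 to compound 2 (0.32 log units; beyond the scatter) as a modest step.

Compound 4 carries a phenyl group as well, so it is expected to resemble compound 1 and compound 2 rather than compound 3. The change therefore runs the large steps in reverse. The expected step is an at least 250-fold lower number from compound 3 to compound 4 (2.39 log units; beyond the scatter) in this assay and it is large, towards a lower number and a stronger inhibitor. Among the measured compounds shown here, only three compounds support this, so the expectation stays broad. For compound 4 the estimate is 20 nM with 6 nM to 80 nM as the expected range.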

Compound 4, half-maximal inhibitory concentration: 3400 nM
For compound 4 the middle estimate is 170-fold (2.23 log units) below the measured one; measured number above the stated range.
By their numbers in this assay, from the lowest: compound 2; then compound 1; then compound 4. At a limit, above all of these: compound 3.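

In this assay a phenyl group on the sulfonyl sulfur turns out not to be enough on its own: moving to 3,5-dichlorophenyl gives a 140-fold higher number from compound 1 to compound 4 (2.13 log units; beyond the scatter) and also a 280-fold higher number from compound 2 to compound 4 (2.45 log units; beyond the scatter) in the same assay. The pattern of groups on the phenyl ring therefore counts for much at this position, since compound 1 and compound 2 are only a modest step apart while compound 4 lies a large step from each. Compound 3 stands at a limit and not a number: the limit of > 5000 nM in this assay, at which 1 of the 4 values shown sits. Putting 3,5-dichlorophenyl in place of 1-methyl-1H-imidazol-4-yl gives an at least 1.4-fold lower number from compound 3 to compound 4 (0.16 log units; that floor lies within the scatter), which is a floor only, so the true size of this step cannot be read.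

The compounds shown give no reason why 3,5-dichlorophenyl behaves so differently from 4-bromo-3-chlorophenyl, and they leave open whether a 3-chlorophenyl or a 3,5-dimethylphenyl group on the sulfur would fall with compound 4 or stay with compound 1 and compound 2. From the compounds shown here alone, it is also open whether a pyridine ring in that place would behave like the 1-methyl-1H-imidazol-4-yl group of compound 3 or like the phenyl groups.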